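This account rests on a few compounds, and the source may have more. Where it says the series, first, only, none or still open, it means among the compounds named here.

Measured so far:
- compound 1 `Cc1ccc(OCC(=O)Nc2ccc(OCC(=O)O)c(F)c2)cc1` — in a functional assay on CHO cells for agonist activity at Free fatty acid receptor 1 (Homo sapiens), read by FLIPR (a higher number here means that more compound is needed for the effect, a lower number that less compound is needed), compound 1 gives 148 nM
- compound 2 `CC(C)(C)c1ccc(OCC(=O)Nc2ccc(OCC(=O)O)c(F)c2)cc1` — in this assay compound 2 gives "not determined" (no result reported), so no result was reported for compound 2

For the measured compounds named here, compound 1 therefore carries the only number in this assay; compound 2 offers nothing to compare it with. The next compound, compound 3 `COc1cccc(OCC(=O)Nc2ccc(OCC(=O)O)c(F)c2)c1`, shares the core of compound 1 and differs from it in one place: 3-methoxyphenyl in place of 4-methylphenyl on an oxygen on a saturated carbon. Going by the values given here, no step between two measured compounds is available to gauge what such a change does in this assay, so the expectation rests on compound 1 alone. Compound 3 is expected to sit close to compound 1, with a modest shift toward needing more compound that may or may not exceed the usual scatter, a step of a 1.7-fold higher number from compound 1 to compound 3 (0.23 log units; within the scatter). Compound 3 is estimated at 250 nM, in a range from 80 nM to 800 nM.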

Compound 3, half-maximal effective concentration: 148 nM
For compound 3 the middle estimate is 1.7-fold (0.23 log units) above the measured one; the measured number falls inside the stated range.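

In this assay, placing 3-methoxyphenyl in place of 4-methylphenyl on an oxygen on a saturated carbon gives no change at the digits printed from compound 1 to compound 3 (within the scatter). For the compounds shown here, this is the first readable step at this position, and it shows that the number holds when the group on that oxygen changes from 4-methylphenyl, with 7 heavy atoms and 0 hydrogen-bond acceptors, to 3-methoxyphenyl, with 8 heavy atoms and 1 hydrogen-bond acceptor. No measurement offers a reason for this result.

Going by these compounds alone, the single step changes both the substituent and its numbered place on the phenyl ring, so the contribution of each remains open. Also open, from the compounds shown here alone, is how this position would respond to groups further from these two, such as 4-methoxyphenyl, a pyridine ring or a phenyl ring carrying an amine.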